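The source may report more compounds than this note shows. Statements on the series, on what has been measured and on what is new or still open speak of the compounds shown alone.

Compound 3 `O=C(NCc1ccc(S(=O)(=O)N2CCCCC2)cc1)c1cnc2nccn2c1` stands second highest of the three numbers in hand: in a functional assay on A2780 cells (Homo sapiens) for inhibition, read by sulforhodamine B assay, with a stated time of 72 h (on this read-out higher numbers stand for weaker inhibition and lower numbers for stronger inhibition), compound 3 gives 130 nM. Compound 2 `O=C(NCc1ccc(S(=O)(=O)N2CCCCC2)cc1)c1cc2cnccc2s1` gives 1600 nM, and compound 1 `O=C(NCc1ccc(S(=O)(=O)c2cc(F)cc(F)c2)cc1)c1cc2ccncc2o1` gives 9 nM. Compound 4 `O=C(NCc1ccc(S(=O)(=O)N2CCCCC2)cc1)c1cc2ccncc2o1` remains unmeasured and differs from compound 3 by a group of 9 heavy atoms (7 carbon, 1 nitrogen, 1 oxygen; one five-membered aromatic ring with 1 hetero atom, one six-membered aromatic ring with 1 hetero atom) in place of a group of 9 heavy atoms (6 carbon, 3 nitrogen; one five-membered aromatic ring with 2 hetero atoms, one six-membered aromatic ring with 2 hetero atoms), on a carbonyl carbon. Within the data shown here, one measured step bears on this position, and it was large: a 12-fold lower number from compound 2 to compound 3 (1.09 log units; beyond the scatter). Among the measured compounds shown here, the group entering in compound 4 is also carried by compound 1, but the sulfonyl part differs, so no direct step exists between them. Given that compound 1 gives 9 nM with this same group, a step toward a lower number is expected for compound 4, around a 3.3-fold lower number from compound 3 to compound 4 (0.51 log units; beyond the scatter). Compound 4 is estimated at 40 nM, within 8 nM to 200 nM.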

Compound 4, half-maximal inhibitory concentration: 29 nM
Compound 4: middle estimate off by 1.4-fold (0.14 log units), on the high side; the range from low to high includes it.
By their numbers in this assay, from the lowest: compound 1; then compound 4; then compound 3; then compound 2.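

With piperidin-1-yl held on the sulfonyl sulfur, the group entering in compound 4 gives the lowest number of the three groups on the carbonyl carbon: a 4.5-fold lower number from compound 3 to compound 4 (0.65 log units; beyond the scatter) and a 55-fold lower number from compound 2 to compound 4 (1.74 log units; beyond the scatter). With that group held, the sulfonyl part can now be read directly: piperidin-1-yl in place of 3,5-difluorophenyl gives a 3.2-fold higher number from compound 1 to compound 4 (0.51 log units; beyond the scatter). No measurement in hand accounts for these steps.

From the compounds shown here alone, it remains open how morpholin-4-yl on the sulfonyl sulfur would compare with piperidin-1-yl and 3,5-difluorophenyl. Going by these compounds, whether the order of groups on the carbonyl carbon holds with 3,5-difluorophenyl on the sulfonyl sulfur is also open.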